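Replacing the fused bicyclic group on the sulfonamide nitrogen

The source may report more compounds than this note shows. Statements on the series, on what has been measured and on what is new or still open speak of the compounds shown alone.

Compound 2 `CCN(CC)C(=O)CN(c1cc2c(C)nsc2cc1Cl)S(=O)(=O)c1ccc(OC)c(OC)c1` gives 29 nM in a functional assay on CHO cells for inhibition of Orexin/Hypocretin receptor type 1 (Homo sapiens), read by FLIPR and calcium flux; on this read-out lower numbers stand for stronger inhibition and higher numbers for weaker inhibition. Among the two plain numbers shown it is the higher one; its nearest neighbour, compound 3 `CCN(C(=O)CN(c1cc2c(C)nsc2cc1Cl)S(=O)(=O)c1ccc(OC)c(OC)c1)c1ccccn1`, gives 8 nM, and the step of a 3.6-fold lower number from compound 2 to compound 3 (0.56 log units; beyond the scatter) is a change on the amide-type nitrogen, not on the sulfonamide nitrogen. Compound 1 `CCN(CC)C(=O)CN(c1ccc(C)cc1)S(=O)(=O)c1cccc(Cl)c1` reaches only a limit of this assay, > 10000 nM, as noted in the limit of > 10000 nM in this assay, at which 1 of the 3 values shown sits.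

Compound 4 `CCN(CC)C(=O)CN(c1cc(N(C)C)ccc1OC)S(=O)(=O)c1ccc(OC)c(OC)c1` differs from compound 2 by a group of 11 heavy atoms (9 carbon, 1 nitrogen, 1 oxygen; one six-membered aromatic ring of carbon only) in place of a group of 11 heavy atoms (8 carbon, 1 nitrogen, 1 sulfur, 1 chlorine; one five-membered aromatic ring with 2 hetero atoms, one six-membered aromatic ring of carbon only), on a sulfonamide nitrogen: a 5-(dimethylamino)-2-methoxyphenyl group replaces the group with one five-membered aromatic ring with 2 hetero atoms and one six-membered aromatic ring, on the sulfonamide nitrogen whose other neighbours are a saturated chain carbon and the sulfonyl sulfur. Within the data shown here, no measured step changes this position, so the measured steps give no direct guide. Compound 1 carries a simple phenyl on that nitrogen but also a different sulfonyl aryl, so its limit says little on its own.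

Compound 4 is expected to give 300 nM, within a range of 40 nM to 3000 nM. This expectation corresponds to a 10-fold higher number from compound 2 to compound 4 (1.01 log units; beyond the scatter).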

Compound 4, half-maximal inhibitory concentration: > 10000 nM
Compound 4 was reported as a limit; the forecaster's own chance of this, stated with the estimate: 15%; middle value at least 33-fold (1.52 log units) away from the limit.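

Putting 5-(dimethylamino)-2-methoxyphenyl on the sulfonamide nitrogen, in place of the group with one five-membered and one six-membered aromatic ring, gives an at least 340-fold higher number from compound 2 to compound 4 (2.53 log units; beyond the scatter) in this assay. The two groups match in heavy-atom count, hydrogen-bond donors, hydrogen-bond acceptors and net charge, so these counts alone do not settle the outcome at this position. The result for compound 4 is a limit of the assay, not a number, and it joins one other compound at that limit: the limit of > 10000 nM in this assay, at which 2 of the 4 values shown sit.

The compounds shown leave open which part of the exchange matters most: the loss of the chlorine, the loss of the five-membered ring, or the arrival of the dimethylamino or methoxy group. A chlorophenyl or a plain methoxyphenyl group on that nitrogen would help separate these possibilities.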